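The source may report more compounds than this note shows. Statements on the series, on what has been measured and on what is new or still open speak of the compounds shown alone.

Among the compounds with values here, compound 1 `NS(=O)(=O)c1ccc(C/N=C/c2ccccc2OCc2cn(CCCOc3ccc4ccc(=O)oc4c3)nn2)cc1` holds the lower of the two numbers so far in a functional assay on HT-29 cells (Homo sapiens) for cytotoxicity, read by MTT assay, with a stated time of 24 h (a higher number here means a weaker inhibitor, a lower number a stronger inhibitor), where compound 1 gives 14300 nM. Within the data shown here, its one measured neighbour, compound 2 `CCN(CC)c1ccc(/C=N/Cc2ccc(S(N)(=O)=O)cc2)c(OCc2cn(CCCOc3ccc4ccc(=O)oc4c3)nn2)c1`, gives 23300 nM in this assay, and that step, a 1.6-fold higher number from compound 1 to compound 2 (0.21 log units; within the scatter), lies within the scatter. Compound 3 `NS(=O)(=O)c1ccc(C/N=C/c2cc([N+](=O)[O-])ccc2OCc2cn(CCCOc3ccc4ccc(=O)oc4c3)nn2)cc1` differs from compound 1 by nitro in place of hydrogen on an aromatic carbon. Among the measured compounds shown here, no measured step involves a nitro group, so the only guide is the small change seen between compound 1 and compound 2. Compound 3 is therefore expected to give 15000 nM in this assay, between 6000 nM and 40000 nM, a step of a 1.0-fold higher number from compound 1 to compound 3 (0.02 log units; within the scatter) that is expected to stay within the scatter.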

Compound 3, half-maximal inhibitory concentration: 117000 nM
For compound 3 the middle estimate is 7.8-fold (0.89 log units) below the measured one; measured number above the stated range.
By their numbers in this assay, from the lowest: compounds 1 and 2 (each within the scatter of the next); then compound 3.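

In this assay, nitro in place of hydrogen on an aromatic carbon, meta to a large group and para to a large group, gives an 8.2-fold higher number from compound 1 to compound 3 (0.91 log units; beyond the scatter), whereas the diethylamino step gave a 1.6-fold higher number from compound 1 to compound 2 (0.21 log units; within the scatter). Within the data shown here, this is the first sign that a single substitution on this ring of the core can weaken the compound beyond the scatter. No evidence here explains the loss. As far as these compounds go, whether it belongs to the nitro group or to this position stays open, as an amine or a methoxy group on the same carbon would be needed to separate the two.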